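The compounds below may be only part of what the source reports. "The series", "measured", "known", "first", "only" and "open" are said of these compounds alone.

Compound 1 `O=C(COCc1ccncc1)N1CCN(c2ccc(Cl)cc2F)CC1`: 600 nM
Compound 2 `Cc1cc(Cl)ccc1N1CCN(C(=O)COCc2ccncc2)CC1`: 240 nM

For the measured compounds named here, in a functional assay on HEK293 cells for positive allosteric modulation of metabotropic glutamate receptor 5 (Homo sapiens), read by FLIPR and calcium flux (on this read-out higher numbers stand for an effect only at larger amounts of compound and lower numbers for an effect already at smaller amounts), compound 2 stands at the lower of the two numbers, with compound 1 as its only neighbour, the step being a 2.5-fold lower number from compound 1 to compound 2 (0.40 log units; beyond the scatter). Compound 3 `O=C(COCc1ccncc1)N1CCN(c2cc(Cl)ccn2)CC1` differs from compound 2 by 4-chloropyridin-2-yl in place of 4-chloro-2-methylphenyl on an amine nitrogen in a ring. Going by the values given here, only one measured step touches this change: a 2.5-fold lower number from compound 1 to compound 2 (0.40 log units; beyond the scatter), where a methyl improved the number; here the methyl departs and no measured step covers the ring nitrogen that enters. A modest move back toward a higher number is therefore expected, as a 3.3-fold higher number from compound 2 to compound 3 (0.52 log units; beyond the scatter). Compound 3 is estimated at 800 nM, between 250 nM and 3000 nM.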

Compound 3, half-maximal effective concentration: 4200 nM
For compound 3 the middle estimate is 5.3-fold (0.72 log units) below the measured one; the measured number lies above the stated range.
By their numbers in this assay, from the lowest: compound 2; then compound 1; then compound 3.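

In this assay, the 4-chloropyridin-2-yl group gives a much larger change than the earlier methyl-for-fluoro swap: an 18-fold higher number from compound 2 to compound 3 (1.24 log units; beyond the scatter) and a 7.0-fold higher number from compound 1 to compound 3 (0.85 log units; beyond the scatter) both point the same way. The group on this amine nitrogen in a ring therefore tolerates far less change than the first step suggested. Nothing at hand gives a reason for this loss. On these data alone, both the methyl and the carbon-only ring change in this one step, so which matters more stays open. So does the effect of a methoxy or trifluoromethyl group in the methyl's place.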